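Compound 2 to compound 4: cytotoxicity at a limit

The source may hold more compounds than are shown below. What is called first, only, known or untested is meant among the compounds shown, and "the series" means these compounds.

Within the data shown here, in an ADME assay on SH-SY5Y cells (Homo sapiens) for cytotoxicity, read by MTT assay, with a stated time of 72 h (on this read-out lower numbers stand for higher toxicity in this test and higher numbers for lower toxicity in this test), none of the three related compounds measured so far gives an exact number. Compound 1 `CN1CCN(Cc2ccccc2Nc2cc(CNCCN3CCCCC3)cc(CNCCN3CCCCC3)c2)CC1` is recorded only as a limit, > 100000 nM. Compound 2 `CN(C)Cc1ccccc1Nc1cc(CNCCN2CCCCC2)cc(CNCCN2CCCCC2)c1` is also recorded only as a limit, > 100000 nM. Compound 3 `CN(C)Cc1ccccc1-c1cc(C(=O)NCCN2CCCCC2)cc(C(=O)NCCN2CCCCC2)c1` is likewise a limit, > 100000 nM. The common feature is the limit of > 100000 nM in this assay, at which 3 of the 3 values shown sit.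

Compound 4 `CN(C)Cc1ccccc1-c1cc(CNCCN2CCCCC2)cc(CNCCN2CCCCC2)c1` has not yet been measured. It carries 2-((dimethylamino)methyl)phenyl in place of the (2-((dimethylamino)methyl)phenyl)amino group of compound 2 (2-((dimethylamino)methyl)phenyl in place of (2-((dimethylamino)methyl)phenyl)amino on an aromatic carbon). Among the measured compounds shown here, the only measured step, a step that the two limits leave unreadable from compound 1 to compound 2, involves a different change and offers no size to carry over. The best guide is therefore compound 2 itself, whose limit of > 100000 nM points to no expected step beyond the scatter in this assay, and another limit is likely. The expected change is a number no higher from compound 2 to compound 4 (the limit leaves the size open). For compound 4 the estimated value is 100000 nM, with an expected range from 50000 nM to 200000 nM.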

Compound 4, half-maximal cytotoxic concentration: > 100000 nM
Compound 4: no number, only a limit; the forecaster's own chance of this, stated with the estimate: 80%; the middle value lies on the limit itself.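

Among these compounds, compound 2 and compound 4 are both recorded only as limits, so no step between them can be read. The compounds shown leave open at what concentration, if any, each would turn toxic to these cells, because all share one result: the limit of > 100000 nM in this assay, at which 4 of the 4 values shown sit.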